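This account rests on a few compounds, and the source may have more. Where it says the series, first, only, none or still open, it means among the compounds named here.

Compounds measured in a functional assay on NCI-H1975 cells (Homo sapiens) for inhibition, read by CellTiter-Glo, with a stated time of 72 h; a lower number here means a stronger inhibitor of growth, a higher number a weaker inhibitor of growth:
- Compound 1, `C=CC(=O)Nc1cc(Nc2ncc(Cl)c(Nc3ccccc3S(=O)(=O)C(C)C)n2)c(OC)cc1N1CCN(S(C)(=O)=O)CC1`: 40 nM
- Compound 2, `C=CC(=O)Nc1cc(Nc2ncc(Cl)c(Nc3ccccc3S(=O)(=O)C(C)C)n2)c(OC)cc1N1CCCN(C)CC1`: 15 nM
- Compound 3, `C=CC(=O)Nc1cc(Nc2ncc(Cl)c(Nc3ccccc3S(=O)(=O)C(C)C)n2)c(OC)cc1N1CCN(C(C)C)CC1`: 25 nM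

Compound 3 sits second highest of the three numbers, and its distances to compound 1 and to compound 2 both lie within the scatter. Compound 4, `C=CC(=O)Nc1cc(Nc2ncc(Cl)c(Nc3ccccc3S(=O)(=O)C(C)C)n2)c(OC)cc1N1CCN(C2CCCCC2)CC1`, differs from compound 3 by cyclohexyl in place of isopropyl on an amine nitrogen in a ring. The measured steps that touch the same ring nitrogen are a 1.6-fold lower number from compound 1 to compound 3 (0.20 log units; within the scatter) and a 1.7-fold higher number from compound 2 to compound 3 (0.22 log units; within the scatter), both small; nothing measured reaches a group as large as cyclohexyl. On that evidence a step no larger than the scatter is expected in this assay, with no direction preferred, so the estimate for compound 4 is 28 nM (range 10 nM to 80 nM), that is, an expected step of a 1.1-fold higher number from compound 3 to compound 4 (0.05 log units; within the scatter).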

Compound 4, concentration for 50% growth inhibition: 77 nM
Estimate against measurement, compound 4: 2.8-fold (0.44 log units) below; low and high end bracket the measured number.
By their numbers in this assay, from the lowest: compounds 2, 3, 1 and 4 (each within the scatter of the next, the first and the last beyond it).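

In this assay, the amine nitrogen in the ring does not treat all carbon groups alike: cyclohexyl in place of isopropyl gives a 3.1-fold higher number from compound 3 to compound 4 (0.49 log units; beyond the scatter), a step beyond the scatter that the earlier changes at this nitrogen did not show. The wider comparison gives a 5.1-fold higher number from compound 2 to compound 4 (0.71 log units; beyond the scatter), whereas a 1.9-fold higher number from compound 1 to compound 4 (0.28 log units; within the scatter) leaves cyclohexyl and methylsulfonyl unresolved at this nitrogen. Nothing available explains these steps. Still open, from the compounds shown here alone, is whether the loss follows the added carbon or the ring itself. Cyclopropyl, a tert-butyl group or a 2-hydroxyethyl chain at this nitrogen would bear on that.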